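Notes on the shared core: fluoro for trifluoromethyl

This account rests on a few compounds, and the source may have more. Where it says the series, first, only, none or still open, it means among the compounds named here.

Of the compounds shown here, three have been measured in a functional assay on BGC-823 cells (Homo sapiens) for antiproliferative activity, read by MTT assay, tested at 1 uM; on this read-out higher numbers stand for a stronger effect at the one concentration tested and lower numbers for a weaker effect. Compound 1 `COc1ccc(C2OC(c3cc(OC)c(OC)c(OC)c3)=NN2C(C)=O)c(OC)c1` gives 6.3%, compound 2 `COc1cc(C2=NN(C(C)=O)C(c3ccccc3C(F)(F)F)O2)cc(OC)c1OC` gives 31.8%, and compound 3 `COc1cc(/C=N/NC(=O)c2cc(OC)c(OC)c(OC)c2)cc(OC)c1OC` gives -5%. Compound 2 stands highest of the three: the step of a number 25.5 percentage points higher from compound 1 to compound 2 (beyond the scatter) lies beyond the scatter, and compound 3 sits further below compound 2 still, a gap that is likewise beyond the scatter.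

Compound 4 `COc1cc(C2=NN(C(C)=O)C(c3ccccc3F)O2)cc(OC)c1OC` has not been measured. It differs from compound 2 in one place: fluoro in place of trifluoromethyl on an aromatic carbon. The change sits on an aromatic carbon of a six-membered aromatic ring of carbon only, ortho to a large group.

Going by the values given here, no measured step bears directly on this change. Among the compounds with values here, the one measured step, a number 25.5 percentage points higher from compound 1 to compound 2 (beyond the scatter), replaces the whole group on the saturated ring carbon and is modest in size; it says nothing about fluoro in place of trifluoromethyl. Within the data shown here, with no precedent, the step of a number 9.8 percentage points lower from compound 2 to compound 4 (within the scatter) is expected to be small, perhaps slightly downward and possibly within the scatter. Compound 4 is therefore estimated at 22%, with a range from 2% to 42%.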

Compound 4, a percentage reported as inhibition, at one concentration (the size of the read-out at that concentration, not a potency): 29.6%
Estimate against measurement, compound 4: 7.6 percentage points below, and the stated range covers the measured number.
By their numbers in this assay, from the lowest: compound 3; then compound 1; then compounds 4 and 2 (each within the scatter of the next).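

In this assay, the step of a number 2.2 percentage points lower from compound 2 to compound 4 (within the scatter) shows that this aromatic carbon, ortho to a large group, accepts fluoro in place of trifluoromethyl with no change beyond the scatter, even though one heavy atom enters where four leave. The step of a number 23.3 percentage points higher from compound 1 to compound 4 (beyond the scatter) shows that 2-fluorophenyl, like 2-(trifluoromethyl)phenyl, reads clearly higher than 2,4-dimethoxyphenyl on the saturated ring carbon, so the earlier rise is not confined to the trifluoromethyl compound. Nothing at hand explains these numbers.

The compounds shown leave open how an amine or a carboxylic acid on the same aromatic carbon would read. They also leave open whether compound 2 and compound 4 would stay level at other concentrations, as one concentration gives no potency.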